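A few compounds are considered here, and "the series" means these few. Any claim that something is new, unique, unknown or untested is made for them only; others in the source may bear on it.

Compounds measured in a functional assay on HT-29 cells (Homo sapiens) for cytotoxicity, read by MTT assay, with a stated time of 72 h; on this read-out higher numbers stand for weaker inhibition and lower numbers for stronger inhibition:
compound 1 `CN(C)CCn1cnnc1-c1cc(Oc2ccc(NC(=O)N/N=C/c3ccc(Cl)cc3Cl)cc2F)ccn1` gives 390 nM
compound 2 `CN(C)CCn1cnnc1-c1cc(Oc2ccc(NC(=O)N/N=C/c3c(Cl)cccc3Cl)cc2F)ccn1` gives 280 nM
compound 3 `CN(C)CCn1cnnc1-c1cc(Oc2ccc(NC(=O)N/N=C/c3cc(C(C)(C)C)cc(C(C)(C)C)c3O)cc2F)ccn1` gives 680 nM

Compound 2 stands at the lowest of the three numbers in this assay. The step of a 1.4-fold lower number from compound 1 to compound 2 (0.14 log units; within the scatter) lies within the scatter, so compounds 1 and 2 are not told apart; compound 3 sits beyond the scatter above compound 2.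

Compound 4 `CN(C)CCn1cnnc1-c1cc(Oc2ccc(NC(=O)N/N=C/c3ccc(O)c(Br)c3)cc2F)ccn1` carries 3-bromo-4-hydroxyphenyl in place of 2,6-dichlorophenyl on a carbon with a double bond to nitrogen. Among the measured compounds shown here, the only measured step on this ring, a 1.4-fold lower number from compound 1 to compound 2 (0.14 log units; within the scatter), was a within-scatter shift between two dichlorophenyl patterns and bears only loosely on a ring bearing a hydroxyl and a bromine. Compound 3, the one measured ring with a hydroxyl, gives 680 nM. Compound 4 is therefore expected at 450 nM, with a range of 180 nM to 1100 nM. The expected step is a 1.6-fold higher number from compound 2 to compound 4 (0.21 log units; within the scatter), not clearly beyond the scatter.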

Compound 4, half-maximal inhibitory concentration: 450 nM
Estimate against measurement, compound 4: no gap at the digits printed; measured number inside the range.
By their numbers in this assay, from the lowest: compounds 2, 1, 4 and 3 (each within the scatter of the next, the first and the last beyond it).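

In this assay, 3-bromo-4-hydroxyphenyl on a carbon with a double bond to nitrogen gives a 1.6-fold higher number from compound 2 to compound 4 (0.21 log units; within the scatter) and a 1.2-fold higher number from compound 1 to compound 4 (0.06 log units; within the scatter), against the two dichlorophenyl rings. Both steps lie within the scatter, so a ring with a hydroxyl and a bromine is not told apart here from either ring with two chlorines. Nothing available accounts for this result. Still open, going by these compounds, is how a ring carrying an amine or a carboxylic acid at this place would read. Also open, on these data alone, is what the hydroxyl and the bromine of compound 4 each contribute alone.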